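The source may report more compounds than this note shows. Statements on the series, on what has been measured and on what is new or still open speak of the compounds shown alone.

Of the compounds shown here, three sharing one core have been measured in a functional assay on NCI-H522 cells (Homo sapiens) for inhibition, read by sulforhodamine B assay, with a stated time of 48 h; on this read-out lower numbers stand for stronger inhibition of growth and higher numbers for weaker inhibition of growth. Compound 1 `CC(C)c1ccc(Nc2ccc3c(OCCCN4CCN(C)CC4)cccc3n2)cc1` gives 19900 nM, compound 2 `CN1CCN(CCCOc2cccc3nc(Nc4ccc(F)c(F)c4)ccc23)CC1` gives 1010 nM, and compound 3 `CN1CCN(CCCOc2cccc3nc(Nc4cc(Cl)cc(Cl)c4)ccc23)CC1` gives 1640 nM. Compound 2 stands at the lowest number of the three, with compound 3 close by and compound 1 far off. Compound 4 `CN1CCN(CCCOc2cccc3nc(Nc4ccc(Cl)c(F)c4)ccc23)CC1` differs from compound 2 by chloro in place of fluoro on an aromatic carbon. The large steps of a 20-fold lower number from compound 1 to compound 2 (1.29 log units; beyond the scatter) and a 12-fold lower number from compound 1 to compound 3 (1.08 log units; beyond the scatter) show that the group on the nitrogen matters greatly, yet the step of a 1.6-fold higher number from compound 2 to compound 3 (0.21 log units; within the scatter) shows two dihalogenated rings giving numbers within the scatter. A swap of one halogen for another is therefore expected to produce no step beyond the scatter in this assay, that is a 1.0-fold lower number from compound 2 to compound 4 (0.00 log units; within the scatter). Compound 4 is estimated at 1000 nM, between 400 nM and 2500 nM.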

Compound 4, concentration for 50% growth inhibition: 1750 nM
Compound 4: the middle estimate sits 1.8-fold (0.24 log units) below what was measured, within the range that was stated.
By their numbers in this assay, from the lowest: compounds 2, 3 and 4 (each within the scatter of the next); then compound 1.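

Chloro in place of fluoro on this aromatic carbon, para to a large group and ortho to a fluoro group, is a single-atom change that stays within the scatter in this assay, with a 1.7-fold higher number from compound 2 to compound 4 (0.24 log units; within the scatter). The 4-chloro-3-fluorophenyl ring also matches the 3,5-dichlorophenyl ring within the scatter, with a 1.1-fold higher number from compound 3 to compound 4 (0.03 log units; within the scatter), yet remains far from 4-isopropylphenyl, with an 11-fold lower number from compound 1 to compound 4 (1.06 log units; beyond the scatter), so all three halogenated rings now stand apart from compound 1. Nothing available explains these results. As far as these compounds go, whether bromo, methoxy or nitrile on this carbon would also stay within the scatter remains open.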